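Branching the indole nitrogen substituent in a 5-alpha-reductase series

The compounds below may be only part of what the source reports. "The series", "measured", "known", "first", "only" and "open" are said of these compounds alone.

Measured compounds:
compound 1, `CCCCn1ccc2cc(/C(C)=C/C(=O)Nc3ccccc3OCCCC(=O)O)ccc21`: 43 nM
compound 2, `C/C(=C\C(=O)Nc1ccccc1OCCCC(=O)O)c1ccc2c(ccn2Cc2ccccc2C)c1`: 69 nM
compound 3, `C/C(=C\C(=O)Nc1ccccc1OCCCC(=O)O)c1ccc2c(ccn2Cc2ccc(F)cc2)c1`: 97 nM

Three compounds share a core and differ only in the group on the aromatic nitrogen. In an assay on Prostate gland for inhibition of steroid 5-alpha-reductase (Rattus norvegicus) (a higher number here means a weaker inhibitor, a lower number a stronger inhibitor), compound 1 gives 43 nM, compound 2 gives 69 nM and compound 3 gives 97 nM. Compound 3 therefore has the highest number of the three, though its gap to compound 2 lies within the scatter, while its gap to compound 1 is modest but real, as a 2.3-fold higher number from compound 1 to compound 3 (0.35 log units; beyond the scatter) shows.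

Compound 4, `CCC(c1ccccc1)n1ccc2cc(/C(C)=C/C(=O)Nc3ccccc3OCCCC(=O)O)ccc21`, is not yet measured. It differs from compound 3 by 1-phenylpropyl in place of 4-fluorobenzyl on an aromatic nitrogen. Going by the values given here, the steps that bear on this change are a 2.3-fold higher number from compound 1 to compound 3 (0.35 log units; beyond the scatter) and a 1.4-fold higher number from compound 2 to compound 3 (0.15 log units; within the scatter); both point to a small effect of swapping one nitrogen substituent for another, and the entering group combines features of the propyl of compound 1 and the arylmethyl groups of compounds 2 and 3. In this assay compound 4 is therefore expected to move by about a 1.5-fold lower number from compound 3 to compound 4 (0.17 log units; within the scatter), toward a slightly lower number. The estimate for compound 4 is 65 nM, with a range from 30 nM to 140 nM.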

Compound 4, half-maximal inhibitory concentration: 19 nM
Estimate against measurement, compound 4: 3.4-fold (0.53 log units) above; measured number outside the range, below it.
By their numbers in this assay, from the lowest: compound 4; then compounds 1, 2 and 3 (each within the scatter of the next, the first and the last beyond it).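

In this assay, going by these compounds alone, the group on the aromatic nitrogen turns out to matter more than the earlier compounds suggested, since 1-phenylpropyl in place of 4-fluorobenzyl gives (a 5.1-fold lower number from compound 3 to compound 4 (0.71 log units; beyond the scatter)) and in place of 2-methylbenzyl gives (a 3.6-fold lower number from compound 2 to compound 4 (0.56 log units; beyond the scatter)). It also improves on the purely aliphatic butyl group (a 2.3-fold lower number from compound 1 to compound 4 (0.35 log units; beyond the scatter)), so compound 4 is the strongest inhibitor of the four, with each of its steps beyond the scatter. No evidence is available to explain why this group lowers the number.

The compounds shown leave open whether the phenyl ring or the propyl chain of this group carries the gain, which a shorter 1-phenylethyl or a ring-free pentan-3-yl group would help separate. They also leave open whether a methoxy group or an amine on that phenyl ring would keep the lower number.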